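This account rests on a few compounds, and the source may have more. Where it says the series, first, only, none or still open, it means among the compounds named here.

Measured so far in a functional assay on MCF7 cells (Homo sapiens) for cytotoxicity, read by sulforhodamine B assay; on this read-out higher numbers stand for weaker inhibition and lower numbers for stronger inhibition:

- compound 1 `C=C1[C@@H](OC(C)=O)C[C@@H]2[C@](C)(CO[Si](C)(C)C(C)(C)C)[C@H](OC(C)=O)CC[C@@]2(C)[C@@H]1C[C@@H](Nc1ccccc1F)C1=CCOC1=O`: 2930 nM
- compound 2 `C=C1[C@@H](OC(C)=O)C[C@@H]2[C@](C)(COC=O)[C@H](OC(C)=O)CC[C@@]2(C)[C@@H]1C[C@@H](Nc1ccc(Br)cc1)C1=CCOC1=O`: 11400 nM
- compound 3 `C=C1[C@@H](OC(C)=O)C[C@@H]2[C@](C)(COC=O)[C@H](OC(C)=O)CC[C@@]2(C)[C@@H]1C[C@@H](Nc1ccccc1C(=O)O)C1=CCOC1=O`: 30800 nM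

Compound 3 stands at the highest number of the three; compound 2 lies nearest, compound 1 furthest, both lower. For the measured compounds named here, the one measured step at the same place is a 2.7-fold higher number from compound 2 to compound 3 (0.43 log units; beyond the scatter), an exchange of the aryl group on the amine nitrogen. Compound 4 `C=C1[C@@H](OC(C)=O)C[C@@H]2[C@](C)(COC=O)[C@H](OC(C)=O)CC[C@@]2(C)[C@@H]1C[C@@H](Nc1ccc(OC)c(OC)c1)C1=CCOC1=O` carries the change (3,4-dimethoxyphenyl in place of 2-carboxyphenyl on an amine nitrogen). A modest fall is expected, a 2.6-fold lower number from compound 3 to compound 4 (0.41 log units; beyond the scatter), because compound 3 holds 30800 nM, the highest number seen, and because the aryl exchange a 2.7-fold higher number from compound 2 to compound 3 (0.43 log units; beyond the scatter) was itself only modest. The estimate for compound 4 in this assay is 12000 nM, with a range from 4000 nM to 35000 nM.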

Compound 4, half-maximal inhibitory concentration: > 50000 nM
Compound 4 was reported as a limit (the forecaster's own chance of this, stated with the estimate: 10%); middle value at least 4.1-fold (0.61 log units) away from the limit.
By their numbers in this assay, from the lowest: compound 1; then compound 2; then compound 3. At a limit, above all of these: compound 4.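

In this assay compound 4 is a limit, not a number: the limit of > 50000 nM in this assay, at which 1 of the 4 values shown sits. Exchanging the aryl group on the amine nitrogen can move the number further than the earlier step showed, with an at least 4.3-fold higher number from compound 2 to compound 4 (0.64 log units; beyond the scatter). The other comparison, an at least 1.6-fold higher number from compound 3 to compound 4 (0.21 log units; that floor lies within the scatter), does not separate the 2-carboxyphenyl and 3,4-dimethoxyphenyl groups.

Open, going by these compounds, is how an unsubstituted phenyl or a benzyl group on this nitrogen would read. Compound 1 differs from the others in more than one place, so its lower number cannot be assigned to either difference.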